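The compounds below may be only part of what the source reports. "The series", "measured", "known", "first", "only" and "open" are said of these compounds alone.

Within the data shown here, compound 1 `Nc1nc(-c2ccco2)nc2sc(CN3CC=CCC3)cc12` is the only member of the series with a figure in a functional assay on the whole organism (strain balb/c) with Mus musculus as the target, with a stated time of 30 min (on this read-out higher numbers stand for an effect only at larger amounts of compound and lower numbers for an effect already at smaller amounts), and gives < 3 mg/kg as a limit of the assay, not a number. Compound 2 `Nc1nc(-c2ccc(C(F)F)o2)nc2sc(CN3CCC(F)CC3)cc12` stands at "not determined" (no result reported) in this assay and so has no single number to start from. Compound 3 `Nc1nc(-c2ccc(C(F)F)o2)nc2sc(CN3CCC(F)(F)CC3)cc12` likewise shows "not determined" (no result reported) there. Compound 4 `N#Cc1cccc(-c2nc(N)c3cc(CN4CCC(F)CC4)sc3n2)c1` differs from compound 2 by 3-cyanophenyl in place of 5-(difluoromethyl)furan-2-yl on an aromatic carbon on the carbon between two ring nitrogen atoms, with 3-cyanophenyl in place of 5-(difluoromethyl)furan-2-yl. Among the measured compounds shown here, no measured step gives a size for this change, so no step beyond the scatter is expected in this assay in either direction. For compound 4 the expected value is 3 mg/kg within an estimated range from 0.8 mg/kg to 10 mg/kg in this read-out.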

Compound 4, dose for half-maximal effect: < 1 mg/kg
Compound 4: a limit, no number (the forecaster's own chance of this, stated with the estimate: 35%); middle value at least 3.0-fold (0.47 log units) from the limit.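

In this assay, among these compounds, compound 4 gives < 1 mg/kg, a limit and not a number, so no step from compound 2 to compound 4 can be read. The compounds shown leave open what size of effect the change from 5-(difluoromethyl)furan-2-yl to 3-cyanophenyl has.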